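Three close cytotoxicity readings and a methylsulfanyl replacement

The compounds below may be only part of what the source reports. "The series", "measured", "known", "first", "only" and "open" are said of these compounds alone.

The three measured compounds share one core and differ only in a single group on an aromatic ring. Compound 1 `O=C(Nc1cccc(N2CCCC2=O)c1)C1CCCN(C(=O)c2cc(C(F)(F)F)cc(C(F)(F)F)c2)C1` carries a 2-oxopyrrolidin-1-yl group, compound 2 `O=C(Nc1cccc(Oc2ccccn2)c1)C1CCCN(C(=O)c2cc(C(F)(F)F)cc(C(F)(F)F)c2)C1` a (pyridin-2-yl)oxy group, and compound 3 `O=C(Nc1cccc([N+](=O)[O-])c1)C1CCCN(C(=O)c2cc(C(F)(F)F)cc(C(F)(F)F)c2)C1` a nitro group. In an ADME assay on PC-3 cells (Homo sapiens) for cytotoxicity, read by WST assay, tested at 100 uM (a lower number here means less inhibition, a higher number more inhibition at the concentration tested (going by the name of the read-out)), compound 1 gives 0%, compound 2 gives 0%, and compound 3 gives 9%. All three numbers sit close together; the step of no change at the digits printed from compound 1 to compound 2 (within the scatter) shows no difference, and the steps of a number 9 percentage points higher from compound 1 to compound 3 (within the scatter) and a number 9 percentage points higher from compound 2 to compound 3 (within the scatter) are both small and within the scatter, so compound 3 cannot be told apart from the other two on these numbers.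

Compound 4 `CSc1cccc(NC(=O)C2CCCN(C(=O)c3cc(C(F)(F)F)cc(C(F)(F)F)c3)C2)c1` continues the series with a further exchange at the same place: methylsulfanyl in place of nitro on an aromatic carbon. For the measured compounds named here, the steps that bear on this are the two that end at compound 3, each of which changed the reading by only a few points. Three different groups at this position have left the reading near zero, so compound 4 is expected to behave the same way, with a step of a number 4 percentage points lower from compound 3 to compound 4 (within the scatter) that stays within the scatter. The estimate for compound 4 is 5%, with a range from 0% to 20%.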

Compound 4, a percentage reported as inhibition, at one concentration (the size of the read-out at that concentration, not a potency): 0%
Compound 4: middle estimate off by 5 percentage points, on the high side, and the stated range covers the measured number.
By their numbers in this assay, from the lowest: compounds 1, 2, 4 and 3 (each within the scatter of the next).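

Methylsulfanyl, a group of carbon and sulfur, takes the place of nitro, a group of nitrogen and oxygen, and in this assay the step is a number 9 percentage points lower from compound 3 to compound 4 (within the scatter). Set against the other two groups, the exchange gives no change at the digits printed from compound 2 to compound 4 (within the scatter) and no change at the digits printed from compound 1 to compound 4 (within the scatter), so all four groups at this place on the aromatic ring now give readings within the scatter of one another, and this sulfur-bearing group does not separate itself from the others. Nothing available here explains why these readings stay together.

The compounds shown leave open whether any group at this place can move the reading beyond the scatter, for example an amine or a carboxylic acid, which would put a different kind of group on the ring. They also leave open how the shared core itself contributes, for instance what happens when a trifluoromethyl group on the other aromatic ring gives way to a chlorine atom, and how these compounds read at any other concentration.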